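This account rests on a few compounds, and the source may have more. Where it says the series, first, only, none or still open, it means among the compounds named here.

Compound 1 `COc1ccc(-c2nc(C)c(C(=O)CSc3nc(-c4ccc(OC)cc4)c(C#N)c(=O)[nH]3)s2)cc1` gives 80.3% in a functional assay on U-87MG ATCC cells for antiproliferative activity against U-87 MG (Homo sapiens), read by MTT assay, with a stated time of 48 h, tested at 10 uM; a lower number here means a stronger effect, a higher number a weaker effect of the compound at the concentration tested. Compound 2 `COc1ccc(-c2nc(SCC(=O)c3sc(-c4ccc(Cl)cc4)nc3C)[nH]c(=O)c2C#N)cc1` gives 88.3%, and the step of a number 8 percentage points higher from compound 1 to compound 2 (within the scatter) lies within the scatter, so the two compounds are not separated on these numbers. Compound 3 `COc1ccc(-c2nc(C)c(C(=O)CSc3nc(-c4cccc(Cl)c4)c(C#N)c(=O)[nH]3)s2)cc1` differs from compound 1 by 3-chlorophenyl in place of 4-methoxyphenyl on an aromatic carbon. For the measured compounds named here, the single measured step exchanges chloro for methoxy at another aromatic carbon of the shared core, so it bears only loosely on this change; its size gives no reason to expect a step beyond the scatter in this assay. Compound 3 is therefore expected at 84%, between 68% and 98%. The expected step is a number 3.7 percentage points higher from compound 1 to compound 3 (within the scatter).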

Compound 3, a percentage reported as activity, at one concentration (the size of the read-out at that concentration, not a potency): 90.6%
Beside the measured number, compound 3's estimate is 6.6 percentage points below it; measured number inside the range.
By their numbers in this assay, from the lowest: compounds 1, 2 and 3 (each within the scatter of the next, the first and the last beyond it).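

In this assay, 3-chlorophenyl in place of 4-methoxyphenyl on the aromatic carbon next to the ring nitrogen gives a number 10.3 percentage points higher from compound 1 to compound 3 (beyond the scatter), a modestly weaker effect. For the compounds shown here, this is the first change to separate two compounds beyond the scatter, and it shows that this position responds to substitution, though on a single pair. No evidence on hand accounts for this step.

The change replaces both the substituent and its place on the phenyl ring, so the two contributions remain unseparated. Going by these compounds, whether an amine such as morpholine or a carboxylic acid at this position would give a stronger effect remains open.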